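The compounds below may be only part of what the source reports. "The series", "measured", "known", "first", "only" and "open" are said of these compounds alone.

Measured compounds:
compound 1 `CCCCc1cnc(C(CCC)Cc2ccc(-c3ccccc3C(=O)O)cc2)[nH]1` — 1180 nM
compound 2 `O=C(O)c1ccccc1-c1ccc(CCc2ncc(C3CCCCC3)[nH]2)cc1` — 375 nM
compound 3 `N#Cc1ccc(Cc2cnc(CCc3ccc(-c4ccccc4C(=O)O)cc3)[nH]2)cc1` — 5890 nM

In an in vitro functional assay on cells for agonist activity at Bombesin receptor subtype-3 (Homo sapiens), read by luminescence and calcium flux (a higher number here means that more compound is needed for the effect, a lower number that less compound is needed), compound 2 stands lowest of the three numbers; compound 1 gives a higher number and compound 3 a much higher one. The new compound 4 `O=C(O)c1ccccc1-c1ccc(CCc2ncc(CCc3ccccc3)[nH]2)cc1` differs from compound 2 at one place: phenethyl in place of cyclohexyl on an aromatic carbon. Among the measured compounds shown here, the one measured step that bears on this change is the exchange of the same cyclohexyl for 4-cyanobenzyl, which gave a 16-fold higher number from compound 2 to compound 3 (1.20 log units; beyond the scatter). Phenethyl, like 4-cyanobenzyl, carries an aromatic ring on a chain, so a rise in the number is expected, though a smaller one, since no nitrile enters. The expected step is a 4.0-fold higher number from compound 2 to compound 4 (0.60 log units; beyond the scatter). Compound 4 is estimated at 1500 nM, with a range from 400 nM to 6000 nM.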

Compound 4, half-maximal effective concentration: 1320 nM
Estimate against measurement, compound 4: 1.1-fold (0.06 log units) above, within the range that was stated.
By their numbers in this assay, from the lowest: compound 2; then compounds 1 and 4 (each within the scatter of the next); then compound 3.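

In this assay, an aromatic ring on a chain at this carbon again gives a higher number than cyclohexyl, with a 3.5-fold higher number from compound 2 to compound 4 (0.55 log units; beyond the scatter). Yet such groups are not equivalent here: the change in the side group gives a 4.5-fold lower number from compound 3 to compound 4 (0.65 log units; beyond the scatter), so the 4-cyanobenzyl group is not the best guide to all aromatic groups at this position. Nothing available explains the size of either step. As far as these compounds go, whether plain benzyl or 4-cyanophenethyl would separate the effect of chain length from that of the nitrile remains open.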